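Moving the sulfur in the benzylic-type thiophene of compound 1

The source may report more compounds than this note shows. Statements on the series, on what has been measured and on what is new or still open speak of the compounds shown alone.

Measured compounds:
compound 1, `Nc1nc(NCc2cccs2)nc2sc(-c3ccco3)nc12`: 12.5 nM
compound 2, `COc1ccccc1CNc1nc(N)c2nc(-c3cccs3)sc2n1`: 17.3 nM
compound 3, `Cc1ccc(-c2nc3c(N)nc(NCc4cccs4)nc3s2)o1`: 71 nM

In an assay on CHO cells for displacement of a labelled ligand from adenosine receptor A1 (Homo sapiens), read by scintillation counting, with a stated time of 90 min (a higher number here means a weaker inhibitor, a lower number a stronger inhibitor), compound 1 gives the lowest of the three numbers. Compound 2 gives 17.3 nM in this assay, within the scatter of compound 1, so no order can be read between these two. Compound 3 stands apart: a 5.7-fold higher number from compound 1 to compound 3 (0.75 log units; beyond the scatter), a modest but real rise.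

Compound 4, `Nc1nc(NCc2ccsc2)nc2sc(-c3ccco3)nc12`, is compound 1 with thiophen-3-yl in place of thiophen-2-yl on a saturated chain carbon bound to a nitrogen on an aromatic ring. Going by the values given here, none of the measured steps touches this part of the molecule; the one real step, from compound 1 to compound 3, changes a methyl on an aromatic carbon elsewhere in the core, and compound 2 differs from compound 1 in more than one place, so it offers no clean comparison. Among the compounds with values here, with no direct precedent, the expectation is conservative: compound 4 is estimated to stay close to compound 1, with a step of a 1.4-fold higher number from compound 1 to compound 4 (0.16 log units; within the scatter), not beyond the scatter. The estimate for compound 4 in this assay is 18 nM, within 6 nM to 60 nM.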

Compound 4, inhibition constant: 8.12 nM
For compound 4 the middle estimate is 2.2-fold (0.35 log units) above the measured one, and the stated range covers the measured number.
By their numbers in this assay, from the lowest: compounds 4, 1 and 2 (each within the scatter of the next, the first and the last beyond it); then compound 3.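

In this assay the exchange at this position gives a 1.5-fold lower number from compound 1 to compound 4 (0.19 log units; within the scatter) and so no order can be read between the two compounds. The earlier single-place step changed a methyl elsewhere in the molecule and lay beyond the scatter, whereas this one shows that thiophen-3-yl can stand in place of thiophen-2-yl on this saturated chain carbon, with the same atoms joined differently, without a change that can be told from the scatter. Nothing available here accounts for this outcome.

The compounds shown leave open whether this position accepts a group other than a thiophene, such as an unsubstituted phenyl, a pyridine ring or a longer chain between the ring and the amine nitrogen. They also leave open whether thiophen-3-yl would behave the same way alongside the methyl of compound 3.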